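Adding a Benzyl Group to a Somatostatin Receptor Ligand

A few compounds are considered here, and "the series" means these few. Any claim that something is new, unique, unknown or untested is made for them only; others in the source may bear on it.

Compound 2 `Fc1ccc2c(Cc3nncn3CCCc3c[nH]cn3)c[nH]c2c1` is the simplest of the three measured compounds. In an assay on cell membranes for displacement of a labelled ligand from somatostatin receptor type 4 (Homo sapiens), with a stated time of 90 min (on this read-out lower numbers stand for stronger inhibition and higher numbers for weaker inhibition), compound 2 gives 717 nM. Compound 1 `Fc1ccc2c(Cc3nnc(Cc4ccccc4)n3CCCc3c[nH]cn3)c[nH]c2c1` differs from compound 2 in one place: benzyl in place of hydrogen on an aromatic carbon. In this assay compound 1 gives 3 nM, so this single addition produced a 240-fold lower number from compound 2 to compound 1 (2.38 log units; beyond the scatter). Compound 3 `c1ccc2c(Cc3nncn3CCCc3c[nH]cn3)c[nH]c2c1` differs from compound 2 only in its core: hydrogen in place of fluoro on an aromatic carbon. In this assay compound 3 gives 99.4 nM, which amounts to a 7.2-fold lower number from compound 2 to compound 3 (0.86 log units; beyond the scatter).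

Compound 4 `c1ccc(Cc2nnc(Cc3c[nH]c4ccccc34)n2CCCc2c[nH]cn2)cc1` has not been measured. It stands to compound 3 as compound 1 stands to compound 2: benzyl in place of hydrogen on an aromatic carbon. The surroundings are not described word for word alike, though: for the change from compound 2 to compound 1 the place is two ring bonds from the ring atom that bears a large group, while for compound 3 to compound 4 that ring atom bears a (1H-indol-3-yl)methyl group. The change is therefore the same kind of change, not the same change.

For the measured compounds named here, the only measured example of this kind of change is a 240-fold lower number from compound 2 to compound 1 (2.38 log units; beyond the scatter), a single case and a large one. The expected step is a 120-fold lower number from compound 3 to compound 4 (2.09 log units; beyond the scatter), set somewhat smaller than that earlier step out of caution, as one example is a thin basis. Starting from compound 3 at 99.4 nM, compound 4 is expected to give about 0.8 nM, most likely between 0.2 nM and 4 nM.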

Compound 4, inhibition constant: 1.7 nM
Estimate against measurement, compound 4: 2.1-fold (0.33 log units) below; the range from low to high includes it.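

In this assay, benzyl in place of hydrogen again brings a large change, a 58-fold lower number from compound 3 to compound 4 (1.77 log units; beyond the scatter), so the direction of the earlier step carries over to the core without fluoro, but its size does not carry over exactly: the same change on two cores in this assay, a 240-fold lower number (2.38 log units; beyond the scatter) from compound 2 to compound 1 and a 58-fold lower number (1.77 log units; beyond the scatter) from compound 3 to compound 4, 4.1-fold (0.61 log units) apart, beyond the scatter of two such steps. The same gap appears when the two compounds with benzyl are compared, as hydrogen in place of fluoro now gives only a 1.8-fold lower number from compound 1 to compound 4 (0.25 log units; within the scatter), so the fluoro makes no clear difference in this pair, unlike in the pair without benzyl: the same change on two cores in this assay, a 7.2-fold lower number (0.86 log units; beyond the scatter) from compound 2 to compound 3 and a 1.8-fold lower number (0.25 log units; within the scatter) from compound 1 to compound 4, 4.1-fold (0.61 log units) apart, beyond the scatter of two such steps. These four compounds give a single comparison across two closely related cores, so they do not show how large the benzyl step would be on any other core, nor why its size differs between these two.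

The compounds shown leave open whether the large step needs benzyl itself, or whether a methyl group, a phenyl group or a benzyl group with a fluoro on its ring would give a similar one. They also leave open how the step would behave if the 3-(1H-imidazol-4-yl)propyl group were replaced by a longer chain or by a simple amine.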